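The compounds below may be only part of what the source reports. "The series", "measured", "known", "first", "only" and "open" are said of these compounds alone.

Compound 1, `CCCCCCCCC(=O)c1cc(O)c(O)c(O)c1`, is the starting point of this account. In a toxicity assay on Vero cells (Chlorocebus sabaeus) (on this read-out higher numbers stand for weaker inhibition and lower numbers for stronger inhibition), compound 1 gives only a limit, > 299000 nM. Compound 2, `CCCCCCCCCCC(=O)c1cc(O)c(O)c(O)c1`, likewise gives only a limit in this assay, > 299000 nM. The step that the two limits leave unreadable from compound 1 to compound 2 cannot be sized because both of its ends rest on (the limit of > 299000 nM in this assay, at which 2 of the 2 values shown sit). The unmeasured compound 3, `CCCCCCCCCCCC(=O)c1cc(O)c(O)c(O)c1`, differs from compound 1 by propyl in place of hydrogen on a saturated chain carbon, eight bonds along the chain from a carbonyl carbon. For the measured compounds named here, the single measured step of a related kind, from compound 1 to compound 2, is unreadable and so gives no direction for the present change; the two limits tell only that both measured compounds sit at the edge of what this assay can report. Compound 3 is therefore expected most likely to sit at that same edge, with an estimated step that the limit leaves unreadable from compound 1 to compound 3. The estimate for compound 3 in this assay is 400000 nM, within an expected range from 150000 nM to 1500000 nM.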

Compound 3, half-maximal inhibitory concentration: > 299000 nM
Compound 3 ended at the assay's limit; the forecaster's own chance of this, stated with the estimate: 80%; the middle value does not contradict the limit.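

For the compounds shown here, compound 3 gives > 299000 nM in this assay, which is only a limit, and no step among compound 1, compound 2 and compound 3 can be read because all three rest on the same limit: the limit of > 299000 nM in this assay, at which 3 of the 3 values shown sit. The compounds shown leave open whether any of the three inhibits at all in this assay.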